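Hydrazone series: hydroxypropyl in place of the aryl group

The source may report more compounds than this note shows. Statements on the series, on what has been measured and on what is new or still open speak of the compounds shown alone.

Measured so far in an assay on isolated protein for inhibition of Dihydrofolate reductase (Homo sapiens); a higher number here means a weaker inhibitor, a lower number a stronger inhibitor:
Compound 1 `COc1ncc(C2c3ccccc3C=NN2C(=O)/C=C/c2cc(Cc3cnc(N)nc3N)cc(OC)c2OC)c(OC)n1` gives > 22000 nM, a limit of this assay.
Compound 2 `COc1cc(Cc2cnc(N)nc2N)cc(/C=C/C(=O)N2N=Cc3ccccc3C2c2ccccc2CN(C)C)c1OC` gives > 42000 nM, again a limit of this assay.

Going by the values given here, compound 2 therefore stands only at a limit, as does the one other value shown, the limit of > 22000 nM in this assay, at which 1 of the 2 values shown sits, and (the limit of > 42000 nM in this assay, at which 1 of the 2 values shown sits). Among the compounds with values here, the one measured step, a step that the two limits leave unreadable from compound 1 to compound 2, is unreadable from these two limits. Compound 3 `COc1cc(Cc2cnc(N)nc2N)cc(/C=C/C(=O)N2N=Cc3ccccc3C2CCCO)c1OC` carries 3-hydroxypropyl in place of 2-((dimethylamino)methyl)phenyl on a saturated ring carbon. With no readable step to go on, compound 3 is expected to remain weak, most likely again at a limit. The expected step is an at least 1.0-fold lower number from compound 2 to compound 3 (0.02 log units; that floor lies within the scatter). For compound 3 the estimate is 40000 nM, with a range of 8000 nM to 200000 nM.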

Compound 3, half-maximal inhibitory concentration: > 25000 nM
Compound 3 gave a limit, no number; the forecaster's own chance of this, stated with the estimate: 70%; the middle value does not contradict the limit.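

In this assay compound 3 gives > 25000 nM, a limit of this assay and not a number. The steps among compound 1, compound 2 and compound 3 therefore cannot be read. On these data alone, whether any group on the saturated ring carbon gives a measurable inhibition stays open.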